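Isopropylsulfonyl for propyl on a weakly active pyrazolopyridine

The source may report more compounds than this note shows. Statements on the series, on what has been measured and on what is new or still open speak of the compounds shown alone.

Of the compounds shown here, two have been tested in a functional assay (aorta) with Oryctolagus cuniculus as the target; on this read-out lower numbers stand for stronger inhibition and higher numbers for weaker inhibition. Compound 1, `OCc1ccnc(-c2nn(Cc3ccccc3F)c3ncccc23)n1`, gives 1300 nM in this assay. Compound 2, `CCCc1cnc(-c2nn(Cc3ccccc3F)c3ncccc23)nc1N`, gives 252000 nM in this assay and so stands at the highest, weakest number of the two, separated from compound 1 by a gap that lies well beyond the usual scatter of repeated measurements.

Compound 3, `CC(C)S(=O)(=O)c1cnc(-c2nn(Cc3ccccc3F)c3ncccc23)nc1N`, has not yet been measured. It differs from compound 2 in one place: isopropylsulfonyl in place of propyl on an aromatic carbon. For the measured compounds named here, nothing measured so far tells how this assay responds to such an exchange, and the large gap between compound 1 and compound 2 comes from a different pattern of substitution altogether, so it gives no direct guide.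

Going by the values given here, with no comparable step available, compound 3 is expected to improve on compound 2 by a moderate step, a 4.2-fold lower number from compound 2 to compound 3 (0.62 log units; beyond the scatter), while remaining far weaker than compound 1. Compound 3 is accordingly estimated at 60000 nM in this assay, within a wide range from 8000 nM to 400000 nM.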

Compound 3, half-maximal inhibitory concentration: 517000 nM
Beside the measured number, compound 3's estimate is 8.6-fold (0.94 log units) below it; the whole stated range lies below it.
By their numbers in this assay, from the lowest: compound 1; then compound 2; then compound 3.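

For the compounds shown here, the exchange gives the first direct reading of this position, on an aromatic carbon ortho to an amino group and para to a large group: in this assay, isopropylsulfonyl in place of propyl gives a 2.1-fold higher number from compound 2 to compound 3 (0.31 log units; beyond the scatter). The entering group brings 6 heavy atoms where propyl has 3 heavy atoms, and 2 hydrogen-bond acceptors, yet the number moves modestly toward weaker inhibition rather than improving, so on this pair the position shows a small response, in the unfavourable direction, to a large change in the group. The data offer no measurement that explains this shift.

The single step joins two changes, the sulfonyl unit and the branching of the chain, and the compounds shown do not separate them; a plain isopropyl or a methylsulfonyl group at this carbon would bear on that question. Also open, as far as these compounds go, is whether any group here, such as a carboxylic acid, an amine or a longer chain, would bring compound 2 and compound 3 closer to the much lower number of compound 1, which differs from them in more than one place.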